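Benzylidene Hydrazone Extension of a Thiosemicarbazide

This account rests on a few compounds, and the source may have more. Where it says the series, first, only, none or still open, it means among the compounds named here.

Compounds measured so far:
compound 1, `CC1=CC[C@@H]([C@@](C)(O)CCCC(C)(C)NC=S)CC1`, > 100000 nM
compound 2, `CC1=CC[C@@H]([C@@](C)(O)CCCC(C)(C)NC(=S)NN)CC1`, > 100000 nM

Both values shown are limits of a functional assay on OVCAR-3 cells (Homo sapiens) for cytotoxicity, read by sulforhodamine B assay (a higher number here means that more compound is tolerated, a lower number that less compound is tolerated), rather than numbers. Compound 1 gives only the limit > 100000 nM in this assay. Compound 2 likewise gives only the limit > 100000 nM in this assay. The step that the two limits leave unreadable from compound 1 to compound 2 therefore cannot be read, because both of its ends sit at the limit of > 100000 nM in this assay, at which 2 of the 2 values shown sit.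

Compound 3, `CC1=CC[C@@H]([C@@](C)(O)CCCC(C)(C)NC(=S)N/N=C\c2ccccc2)CC1`, differs from compound 2 by a group of 8 heavy atoms (7 carbon, 1 nitrogen; one six-membered aromatic ring of carbon only) in place of one nitrogen atom, on an amide-type nitrogen. Within the data shown here, no measured step bears on this change; the single step on record is unreadable, so compound 2 offers only a limit as a starting point. The expectation for compound 3 rests on the structural change alone. Compound 3 is expected to give 50000 nM in this assay, within a range from 10000 nM to 200000 nM. The step of an at least 2.0-fold lower number from compound 2 to compound 3 (0.30 log units; that floor lies within the scatter) is thus estimated to run toward less tolerance, though the result may well remain a limit.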

Compound 3, concentration lethal to 50% of the cells: 43600 nM
Compound 3: middle estimate off by 1.1-fold (0.06 log units), on the high side; low and high end bracket the measured number.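

Among these compounds, on the amide-type nitrogen, the group of 8 heavy atoms with its six-membered aromatic ring gives the first number in this assay that is not a limit, with an at least 2.2-fold lower number from compound 2 to compound 3 (0.36 log units; beyond the scatter) as the step. On the thiocarbonyl carbon, the group in place of a hydrogen atom shows the same picture, with an at least 2.2-fold lower number from compound 1 to compound 3 (0.36 log units; beyond the scatter) as the step. Both sizes are floors, as each step starts from a limit and not from a number: the limit of > 100000 nM in this assay, at which 2 of the 3 values shown sit.

The compounds shown leave open how much of this step belongs to the aromatic ring and how much to the double bond outside it. A cyclohexyl group in place of the ring, or a chloro or methoxy group on it, would bear on that question.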